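The source may report more compounds than this note shows. Statements on the series, on what has been measured and on what is new or still open speak of the compounds shown alone.

Of the compounds shown here, three have so far been measured in a functional assay on SF-539 cells (Homo sapiens) for cytotoxicity, read by sulforhodamine B assay, with a stated time of 48 h; on this read-out lower numbers stand for stronger inhibition of growth and higher numbers for weaker inhibition of growth. Compound 1 `ClCc1ccc(Cn2cnc3c(Cl)ncnc32)cc1` gives 2340 nM in this assay, compound 2 `ClCc1ccccc1Cn1cnc2c(Cl)nc(Cl)nc21` gives 1470 nM, and compound 3 `ClCc1cccc(Cn2cnc3c(Cl)ncnc32)c1` gives 20000 nM. Compound 3 thus stands highest of the three, and its distance from both compound 1 and compound 2 lies beyond the scatter. Compound 4 `ClCc1cccc(Cn2cnc3c(Cl)nc(Cl)nc32)c1` differs from compound 3 by chloro in place of hydrogen on an aromatic carbon. Among the compounds with values here, no measured pair shows this change alone; compound 2 also carries two chloro groups on the core but differs from compound 3 in a second place as well, so its number does not isolate the change. A modest lowering is nevertheless expected, estimated as a step of a 2.5-fold lower number from compound 3 to compound 4 (0.40 log units; beyond the scatter). Compound 4 is accordingly expected to give 8000 nM in this assay, within a range from 2000 nM to 25000 nM.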

Compound 4, concentration for 50% growth inhibition: 2180 nM
The estimate for compound 4 lay 3.7-fold (0.56 log units) above the measured number; the measured number falls inside the stated range.
By their numbers in this assay, from the lowest: compounds 2, 4 and 1 (each within the scatter of the next); then compound 3.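

In this assay, within the data shown here, chloro in place of hydrogen on the aromatic carbon between two ring nitrogen atoms gives a 9.2-fold lower number from compound 3 to compound 4 (0.96 log units; beyond the scatter) and so provides the first single-place step. It shows that this carbon is not indifferent to substitution, since one added chlorine atom moves the number beyond the scatter. Nothing available explains this drop. Going by these compounds, whether an amine, a methoxy group or a fluoro group on this carbon would lower the number as far as chloro remains open. This single pair also cannot show whether the step carries over to other compounds.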